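Adding a Methoxy Group to the Weaker Aryl Lactone

The source may hold more compounds than are shown below. What is called first, only, known or untested is meant among the compounds shown, and "the series" means these compounds.

Compound 1: `COc1ccc(/C=C/C2CC=CC(=O)O2)c(OC)c1` — 15.8 uM
Compound 2: `COc1ccc(/C=C/C2CC=CC(=O)O2)cc1OC` — 63 uM

The two measured compounds share one core and differ only in where their methoxy groups sit. In an ADME assay on HaCaT cells (Homo sapiens) for inhibition, read by sulforhodamine B assay, with a stated time of 48 h (on this read-out lower numbers stand for stronger inhibition of growth and higher numbers for weaker inhibition of growth), compound 1 gives 15.8 uM, while compound 2 gives 63 uM, the highest of the two numbers; the gap between compound 1 and compound 2 lies beyond the usual scatter, so compound 2 is the weaker inhibitor of growth of the pair. Compound 3, `COc1cc(OC)c(OC)cc1/C=C/C1CC=CC(=O)O1`, has not yet been measured. It differs from compound 2 by methoxy in place of hydrogen on an aromatic carbon, the new group standing on an aromatic carbon, ortho to a group of 9 heavy atoms, meta to a methoxy group and para to a methoxy group. Within the data shown here, no step between measured compounds shows what such a change does here. In this assay the expected step is modest, a 1.6-fold lower number from compound 2 to compound 3 (0.20 log units; within the scatter), leaning toward lower numbers but not clearly beyond the scatter. Compound 3 is therefore estimated at 40 uM, within 12 uM to 130 uM.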

Compound 3, concentration for growth inhibition (reported as GI): 46.9 uM
Compound 3: middle estimate off by 1.2-fold (0.07 log units), on the low side; the measured number falls inside the stated range.
By their numbers in this assay, from the lowest: compound 1; then compounds 3 and 2 (each within the scatter of the next).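

In this assay, methoxy in place of hydrogen on the aromatic carbon ortho to a group of 9 heavy atoms and para to a methoxy group gives a 1.3-fold lower number from compound 2 to compound 3 (0.13 log units; within the scatter) and so leaves compound 2 and compound 3 inseparable at this position. Read from compound 1, the same kind of change gives a 3.0-fold higher number from compound 1 to compound 3 (0.47 log units; beyond the scatter) and so carries a cost beyond the scatter, which shows that the outcome of adding a methoxy group depends on which compound receives it. No measurement shown here offers a reason for either step.

The compounds shown carry only hydrogen or methoxy at this position, so it remains open whether a hydroxyl group, an amine or a longer alkoxy chain there would separate from compound 2. Whether any such group would reach the level of compound 1 is also unanswered.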